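The source may report more compounds than this note shows. Statements on the series, on what has been measured and on what is new or still open speak of the compounds shown alone.

Series notes. The shared core of compound 1 `Cc1nn(-c2ccc3onc(N)c3c2)c2c(F)c(-c3ccc(N4CCCCC4=O)cc3F)ccc12` is carried through the set. In an assay on isolated protein for inhibition of Trypsin (Homo sapiens) (a higher number here means a weaker inhibitor, a lower number a stronger inhibitor), compound 1 gives > 10000 nM, a limit of the assay. Compound 2 `CN(C)Cc1[nH]ncc1-c1ccc(-c2ccc3c(C(N)=O)nn(-c4ccc5onc(N)c5c4)c3c2F)c(F)c1` is measured in this assay at > 10000 nM, again a limit. Compound 3 `CN(C)Cc1ccncc1-c1ccc(-c2ccc3c(C(N)=O)nn(-c4ccc5onc(N)c5c4)c3c2F)c(F)c1` stands in this assay at > 10000 nM, also a limit. The step that the two limits leave unreadable from compound 2 to compound 3 therefore cannot be read. Compound 3 thus sits at the limit where all three values sit (the limit of > 10000 nM in this assay, at which 3 of the 3 values shown sit); no number places it. Compound 4 `CN(C)CCN(c1ccccc1)c1ccc(-c2ccc3c(C(N)=O)nn(-c4ccc5onc(N)c5c4)c3c2F)c(F)c1` differs from compound 3 by (2-(dimethylamino)ethyl)(phenyl)amino in place of 4-((dimethylamino)methyl)pyridin-3-yl on an aromatic carbon. Within the data shown here, no measured step in this assay carries a readable size, since both ends of a step that the two limits leave unreadable from compound 2 to compound 3 are limits, so nothing sets a direction or size for this change. The expectation for compound 4 in this assay is a value at or beyond the limit, estimated at 20000 nM with a range of 5000 nM to 100000 nM. The implied step is expected to be a step that the limit leaves unreadable from compound 3 to compound 4, most likely reported again only as a limit.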

Compound 4, inhibition constant: > 10000 nM
Compound 4 ended at the assay's limit; the forecaster's own chance of this, stated with the estimate: 85%; the middle value lies beyond the limit too.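

In this assay compound 4 gives > 10000 nM as a limit of the assay. The steps from compound 2 and from compound 3 to compound 4 therefore cannot be read. The compounds shown leave open how far any of them lies beyond the limit, and which change on the shared core would give a readable value.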